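Hydrazone aryl variation on the shared core

A few compounds are considered here, and "the series" means these few. Any claim that something is new, unique, unknown or untested is made for them only; others in the source may bear on it.

Compound 2, `CC1CC/C(=N\Nc2ccc(I)cc2)c2ncc(C(=O)O)c(=O)n21`, carries 4-iodophenyl on an amine nitrogen of the shared core. In a functional assay on the whole organism for inhibition, with Rattus norvegicus as the target (a higher number here means that more compound is needed for the effect, a lower number that less compound is needed), compound 2 gives only a limit, > 1000 umol/kg. Its neighbour compound 1, `CC1CC/C(=N\Nc2ccccc2Br)c2ncc(C(=O)O)c(=O)n21`, carries 2-bromophenyl at the same nitrogen. In this assay compound 1 likewise gives only a limit, > 320 umol/kg. Among the compounds with values here, the single measured step, a step that the two limits leave unreadable from compound 1 to compound 2, is therefore not readable in size, as both the limit of > 1000 umol/kg in this assay, at which 1 of the 2 values shown sits, and the limit of > 320 umol/kg in this assay, at which 1 of the 2 values shown sits, show: the two values sit at limits and the gap between them cannot be stated.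

Compound 3, `Cc1ccccc1N/N=C1\CCC(C)n2c1ncc(C(=O)O)c2=O`, is the next member. It differs from compound 2 by 2-methylphenyl in place of 4-iodophenyl on an amine nitrogen. Within the data shown here, no measured step bears readably on this change; the one step that exists is unreadable, so neither a direction nor a size beyond the scatter can be drawn from it. The expectation can only be that compound 3 stays near where compound 2 stands, with a wide range. The step of an at least 1.6-fold lower number from compound 2 to compound 3 (0.22 log units; that floor lies within the scatter) is accordingly expected to show nothing beyond the scatter. For compound 3 in this assay the estimate is 600 umol/kg, between 100 umol/kg and 3000 umol/kg, and a limit rather than a number is the likelier outcome.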

Compound 3, dose for 50% inhibition: > 100 umol/kg
Compound 3: a limit, no number (the forecaster's own chance of this, stated with the estimate: 75%); the middle value lies beyond the limit too.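

In this assay compound 3 gives only a limit, > 100 umol/kg, so its steps from compound 1 and from compound 2 cannot be read. The compounds shown leave open how far these three compounds stand apart and whether any aryl group on this amine nitrogen of the shared core gives a number rather than a limit.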